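Urea replaces amide: compound 4 in a 5-HT1D series

The source may report more compounds than this note shows. Statements on the series, on what has been measured and on what is new or still open speak of the compounds shown alone.

Compound 3 `CN1CCC(c2c[nH]c3ccc(NC(=O)c4ccc([N+](=O)[O-])cc4)nc23)CC1` gives 340 nM in an assay for binding affinity to 5-hydroxytryptamine receptor 1D (Homo sapiens), read by radioligand binding; a higher number here means a weaker inhibitor, a lower number a stronger inhibitor. Among the measured compounds shown here, that puts it second highest of the three numbers so far: compound 1 `CCCCCCCC(=O)Nc1ccc2[nH]cc(C3CCN(C)CC3)c2n1` gives 110 nM, and compound 2 `CN1CCC(c2c[nH]c3ccc(NC(=O)c4cccc(F)c4)nc23)CC1` gives 690 nM. The step of a 3.1-fold higher number from compound 1 to compound 3 (0.49 log units; beyond the scatter) and the step of a 2.0-fold lower number from compound 2 to compound 3 (0.31 log units; beyond the scatter) both bear on how an aromatic ring on the carbonyl carbon behaves in this assay; the step of a 6.3-fold higher number from compound 1 to compound 2 (0.80 log units; beyond the scatter) shows the same direction from the heptyl chain.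

Compound 4 `CN1CCC(c2c[nH]c3ccc(NC(=O)Nc4ccc(F)cc4)nc23)CC1` differs from compound 3 in one place: (4-fluorophenyl)amino in place of 4-nitrophenyl on a carbonyl carbon. For the measured compounds named here, no measured step swaps an aromatic ring for an arylamino group on the carbonyl carbon, so the only guide is that the aromatic amides of compound 2 and compound 3 sit within a modest span of each other, both weaker than compound 1. Compound 4 is therefore expected to stay in that aromatic range, with a step of a 1.5-fold higher number from compound 3 to compound 4 (0.17 log units; within the scatter) towards a somewhat higher number and wide uncertainty. Compound 4 is estimated at 500 nM, within 150 nM to 1600 nM.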

Compound 4, inhibition constant: 3.8 nM
For compound 4 the middle estimate is 130-fold (2.12 log units) above the measured one; the whole stated range lies above it.
By their numbers in this assay, from the lowest: compound 4; then compound 1; then compound 3; then compound 2.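

Among the compounds shown here, replacing the aromatic ring on the carbonyl carbon with (4-fluorophenyl)amino turns the amide into a urea, and this is the first change at this position to give a large drop in the number in this assay: an 89-fold lower number from compound 3 to compound 4 (1.95 log units; beyond the scatter) and a 180-fold lower number from compound 2 to compound 4 (2.26 log units; beyond the scatter) in the two comparisons with aromatic amides. For the compounds shown here, the arylamino group also overtakes the heptyl chain, which had the lowest number so far, with a 29-fold lower number from compound 1 to compound 4 (1.46 log units; beyond the scatter), so the earlier order of heptyl ahead of both aromatic rings does not extend to compound 4. No evidence at hand explains the size of these steps.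

From the compounds shown here alone, it remains open whether the steps belong to the added amino nitrogen or to the 4-fluorophenyl ring, which a 4-fluorophenyl group directly on the carbonyl carbon would help to separate. Going by these compounds, it is equally open whether a heptylamino chain on the same carbon would follow compound 4 or compound 1.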